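Replacing a catechol by a dichlorophenyl on a semicarbazone

The source may report more compounds than this note shows. Statements on the series, on what has been measured and on what is new or still open speak of the compounds shown alone.

This series shares a diaryl ether core carrying a semicarbazone arm, as seen in compound 1 `COc1ccc(/C=N/NC(=O)Nc2ccc(Oc3ccnc(-c4nncn4CCN(C)C)c3)c(F)c2)c(OC)c1`. In an ADME assay on WI-38 cells (Homo sapiens) for cytotoxicity, read by MTT assay, with a stated time of 72 h (a higher number here means a weaker inhibitor, a lower number a stronger inhibitor), compound 1 gives 6630 nM. Compound 2 `CN(C)CCn1cnnc1-c1cc(Oc2ccc(NC(=O)N/N=C/c3ccc(O)c(O)c3)cc2F)ccn1` carries a 3,4-dihydroxyphenyl on the semicarbazone; in this assay compound 2 stands at "not determined" (no result reported), so no number anchors it, and the only figure available in the set is that of compound 1. Compound 3 `CN(C)CCn1cnnc1-c1cc(Oc2ccc(NC(=O)N/N=C/c3cccc(Cl)c3Cl)cc2F)ccn1` differs from compound 2 by 2,3-dichlorophenyl in place of 3,4-dihydroxyphenyl on a carbon with a double bond to nitrogen. For the measured compounds named here, with no measured step between compounds that differ in one place, the size and direction of the change from compound 2 to compound 3 cannot be read from the data; the nearest reference is the value of compound 1. On that basis compound 3 is expected to give about 5000 nM in this assay, within a range from 1500 nM to 20000 nM.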

Compound 3, half-maximal inhibitory concentration: 6130 nM
Compound 3: the middle estimate sits 1.2-fold (0.09 log units) below what was measured, within the range that was stated.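

In this assay, for the compounds shown here, putting 2,3-dichlorophenyl in place of 2,4-dimethoxyphenyl on a carbon with a double bond to nitrogen gives a 1.1-fold lower number from compound 1 to compound 3 (0.03 log units; within the scatter), the first measured step at this position, and it does not separate the two groups. The two aryl groups differ in their substituents, chlorine against methoxy, yet their readings lie within the scatter of each other, so this cytotoxicity read-out shows no distinction between them. Nothing in the data explains this result.

On these data alone, the step from compound 2 to compound 3 cannot be read, so what the 3,4-dihydroxyphenyl group does in this assay stays unknown. As far as these compounds go, it also remains open whether an aryl group carrying an amine or a carboxylic acid at this position would move the number beyond the scatter.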